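A 2-nitrophenyl swap at the carbonyl carbon of compound 3

This account rests on a few compounds, and the source may have more. Where it says the series, first, only, none or still open, it means among the compounds named here.

Measured so far in a functional assay on MCF7 cells (Homo sapiens) for antiproliferative activity, read by MTT assay, with a stated time of 72 h; a higher number here means a weaker inhibitor, a lower number a stronger inhibitor:
- Compound 1 `CC1=CC[C@H]2[C@H](CC[C@]2(C)O)C(C)(C)[C@@H]1CC[C@H]1[C@]2(C)CC[C@H](OC(=O)c3ccc(C)cc3)C(C)(C)O[C@H]2CC[C@@]1(C)O` gives > 50000 nM as a limit of the assay
- Compound 2 `CC1=CC[C@H]2[C@H](CC[C@]2(C)O)C(C)(C)[C@@H]1CC[C@H]1[C@]2(C)CC[C@H](OC(=O)NS(=O)(=O)c3ccc(C)cc3)C(C)(C)O[C@H]2CC[C@@]1(C)O` gives > 50000 nM as a limit of the assay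
- Compound 3 `CC1=CC[C@H]2[C@H](CC[C@]2(C)O)C(C)(C)[C@@H]1CC[C@H]1[C@]2(C)CC[C@H](OC(=O)c3ccc(C(F)(F)F)cc3)C(C)(C)O[C@H]2CC[C@@]1(C)O` gives 23400 nM as a measured number

Compound 3 is the only one of the three with a number rather than a limit, and it is the most potent of them. The rest of the set sits at the limit of > 50000 nM in this assay, at which 2 of the 3 values shown sit, and shows no size of effect.

The step to compound 4 `CC1=CC[C@H]2[C@H](CC[C@]2(C)O)C(C)(C)[C@@H]1CC[C@H]1[C@]2(C)CC[C@H](OC(=O)c3ccccc3[N+](=O)[O-])C(C)(C)O[C@H]2CC[C@@]1(C)O` is made at one place 2-nitrophenyl in place of 4-(trifluoromethyl)phenyl on a carbonyl carbon and puts 2-nitrophenyl in place of 4-(trifluoromethyl)phenyl on a carbonyl carbon.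

Among the measured compounds shown here, two measured steps bear on it. Exchanging the group at this same place gave an at least 2.1-fold lower number from compound 2 to compound 3 (0.32 log units; beyond the scatter) and is the closer precedent. Putting trifluoromethyl in place of methyl on an aromatic carbon gave an at least 2.1-fold lower number from compound 1 to compound 3 (0.32 log units; beyond the scatter), and that group now leaves. Both steps end at compound 3 and neither has an exact size. The remaining step is a step that the two limits leave unreadable from compound 1 to compound 2 and adds nothing.

A modest move toward a higher number in this assay is therefore expected, quite possibly ending at the limit. The expected change is a 1.7-fold higher number from compound 3 to compound 4 (0.23 log units; within the scatter) and it is estimated as modest. For compound 4 the estimated value is 40000 nM within an expected range from 15000 nM to 90000 nM as the likely span.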

Compound 4, half-maximal inhibitory concentration: 5200 nM
Compound 4: the middle estimate sits 7.7-fold (0.89 log units) above what was measured; measured number below the stated range.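

In this assay, exchanging 4-(trifluoromethyl)phenyl for 2-nitrophenyl on the carbonyl carbon gives a 4.5-fold lower number from compound 3 to compound 4 (0.65 log units; beyond the scatter), so this place can shift the number further than compound 3 alone could show. Among the compounds shown here, because compound 1 and compound 2 carry limits, the earlier steps gave only a lower bound on the effect of changing this group, and the new compound raises that bound, with an at least 9.6-fold lower number from compound 2 to compound 4 (0.98 log units; beyond the scatter) and an at least 9.6-fold lower number from compound 1 to compound 4 (0.98 log units; beyond the scatter). Activity at this place is therefore not confined to the edge of the readable range, where much of the set still stands: the limit of > 50000 nM in this assay, at which 2 of the 4 values shown sit.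

As far as these compounds go, whether the gain belongs to the nitro group itself or to where it stands on the ring remains open, since compound 3 and compound 4 differ in both the substituent and its place on the ring. Also open, from the compounds shown here alone, are how a plain phenyl group or a pyridine ring would read on this carbonyl carbon, and whether the order seen here holds in other cell lines.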